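Swapping Difluorophenyl for Dimethylphenyl on a Soluble Scaffold

A few compounds are considered here, and "the series" means these few. Any claim that something is new, unique, unknown or untested is made for them only; others in the source may bear on it.

Compound 1 `Cc1oc(-c2c(F)cccc2F)nc1CN1CCC(C(=O)NCCCN2C[C@H](C)C[C@H](C)C2)CC1` was tested in a physicochemical assay for solubility, in phosphate buffer, measured as kinetic solubility, at pH 7.4; a lower number here means a less soluble compound, a higher number a more soluble compound. In this assay compound 1 gives > 72 ug/mL, which is a limit of the assay rather than a number. Compound 2 `Cc1ccccc1-c1nc(CN2CCC(C(=O)NCCCN3CC4CCCC(C4)C3)CC2)c(C)o1` gives > 71 ug/mL, again a limit and not a number. Compound 3 `Cc1ccccc1-c1nc(CN2CCC(C(=O)NCCCCN3C[C@H](C)C[C@H](C)C3)CC2)c(C)o1` gives > 71 ug/mL, also a limit. Going by the values given here, the single one-point comparison available, a step that the two limits leave unreadable from compound 2 to compound 3, therefore cannot be read, since both of its ends sit at limits. Compound 1 thus stands exactly where the other two measured compounds stand, at a limit, as the limit of > 72 ug/mL in this assay, at which 1 of the 3 values shown sits, and the limit of > 71 ug/mL in this assay, at which 2 of the 3 values shown sit, show.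

Compound 4 `Cc1ccc(-c2nc(CN3CCC(C(=O)NCCCN4C[C@H](C)C[C@H](C)C4)CC3)c(C)o2)cc1C` differs from compound 1 in one place: 3,4-dimethylphenyl in place of 2,6-difluorophenyl on an aromatic carbon. Among the compounds with values here, no measured step touches this part of the molecule, and the only step available, a step that the two limits leave unreadable from compound 2 to compound 3, alters a distant saturated ring and is itself unreadable. With all three measured values at limits, no direction of change can be argued from the data. Compound 4 is expected to give 70 ug/mL, within a range from 30 ug/mL to 100 ug/mL, which means an expected step of an at least 1.0-fold lower number from compound 1 to compound 4 (0.01 log units; that floor lies within the scatter), with the measurement most likely stopping again at a limit.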

Compound 4, solubility: > 71 ug/mL
Compound 4 ended at the assay's limit; the forecaster's own chance of this, stated with the estimate: 65%; at least 1.0-fold (0.00 log units) between middle value and limit.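

In this assay compound 4 gives > 71 ug/mL, a limit and not a number. Compound 1 also sits at a limit, and the step between compound 1 and compound 4 cannot be read. The compounds shown leave open how 3,4-dimethylphenyl and 2,6-difluorophenyl compare in this assay.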